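Methyl for fluoro on the aryl of compound 2

This account rests on a few compounds, and the source may have more. Where it says the series, first, only, none or still open, it means among the compounds named here.

Going by the values given here, compound 2 `CCCc1nc(-c2ccccc2)c(CNCCCN2CCN(c3ccccc3F)CC2)o1` gives 16100 nM in an assay on HEK293 cells for inhibition of Voltage-dependent T-type calcium channel subunit alpha-1G (Homo sapiens), read by patch clamp (a higher number here means a weaker inhibitor, a lower number a stronger inhibitor), the highest of the two numbers so far; compound 1 `CCCc1nc(-c2ccccc2)c(CNCCCN2CCN(c3ccc(C(F)(F)F)cc3)CC2)o1` gives 7250 nM, and the step of a 2.2-fold higher number from compound 1 to compound 2 (0.35 log units; beyond the scatter) came with 2-fluorophenyl in place of 4-(trifluoromethyl)phenyl on an amine nitrogen in a ring. Compound 3 `CCCc1nc(-c2ccccc2)c(CNCCCN2CCN(c3ccccc3C)CC2)o1` differs from compound 2 by methyl in place of fluoro on an aromatic carbon. Among the compounds with values here, no measured step swaps one small group for another on that ring, and the single known step changes the group and its placement together, so it bears on this change only loosely. Compound 3 is therefore expected to give a step of a 1.2-fold lower number from compound 2 to compound 3 (0.06 log units; within the scatter) with no clear direction beyond the scatter. The estimate for compound 3 is 14000 nM, within 6000 nM to 35000 nM.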

Compound 3, half-maximal inhibitory concentration: 8750 nM
Beside the measured number, compound 3's estimate is 1.6-fold (0.20 log units) above it; low and high end bracket the measured number.
By their numbers in this assay, from the lowest: compounds 1, 3 and 2 (each within the scatter of the next, the first and the last beyond it).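

In this assay, methyl in place of fluoro on an aromatic carbon, ortho to a large group, gives a 1.8-fold lower number from compound 2 to compound 3 (0.26 log units; within the scatter), so this swap does not separate the two groups beyond repeat-measurement scatter. 2-Methylphenyl in place of 4-(trifluoromethyl)phenyl gives a 1.2-fold higher number from compound 1 to compound 3 (0.08 log units; within the scatter), which places compound 3 within the scatter of both compound 1 and compound 2, although those two lie beyond the scatter of each other. No available measurement accounts for these numbers. Still open, going by these compounds, is whether a chloro, methoxy or hydroxyl group on this carbon, or an unsubstituted phenyl, would read differently.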